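The source may hold more compounds than are shown below. What is called first, only, known or untested is meant among the compounds shown, and "the series" means these compounds.

Compound 1 `CCn1nc(Cl)c2ccc(N/C(C)=C3\C(=O)C=C(C)OC3=O)cc21` and compound 2 `C=CCn1nc(Cl)c2ccc(N/C(C)=C3\C(=O)C=C(C)OC3=O)cc21` share one core and differ in a single group: vinyl in place of methyl on a saturated chain carbon bound to an aromatic nitrogen. In an ADME assay on RAW264.7 cells (Mus musculus) for cytotoxicity, read by resazurin assay, with a stated time of 48 h (on this read-out higher numbers stand for lower toxicity in this test and lower numbers for higher toxicity in this test), compound 1 gives 6230 nM. For compound 2 this assay reports only a limit, > 100000 nM. From the compounds shown here alone, that amounts to an at least 16-fold higher number from compound 1 to compound 2 (1.20 log units; beyond the scatter), and the true size of this step stays open because of the limit of > 100000 nM in this assay, at which 2 of the 3 values shown sit.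

Compound 3 `CCn1cc2ccc(N/C(C)=C3\C(=O)C=C(C)OC3=O)cc2n1` is built on a different core; the difference between the two cores is not broken down here. For compound 3 this assay again reports only a limit, > 100000 nM.

Compound 4 `C=CCn1cc2ccc(N/C(C)=C3\C(=O)C=C(C)OC3=O)cc2n1` has not yet been measured. It arises from compound 3 by the same change that turned compound 1 into compound 2, at the same place: vinyl in place of methyl on a saturated chain carbon bound to an aromatic nitrogen. In the measured pair this change moved the number a long way toward lower toxicity, and compound 3 already sits at the limit of this assay. A step that the limit leaves unreadable from compound 3 to compound 4 is therefore expected, which most likely means another limit rather than a number. Compound 4 is expected to give roughly 150000 nM, somewhere between 60000 nM and 400000 nM.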

Compound 4, half-maximal cytotoxic concentration: > 100000 nM
Compound 4 gave a limit, no number (the forecaster's own chance of this, stated with the estimate: 85%); the middle value is on the limit's open side.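

Compound 3 and compound 4 both end at a limit in this assay rather than at a number, so no step can be read between them: the limit of > 100000 nM in this assay, at which 3 of the 4 values shown sit.

From the compounds shown here alone, whether vinyl in place of methyl changes toxicity on the core of compound 3 as it did on the core of compound 1 stays open, as do the true values behind these limits.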